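The source may hold more compounds than are shown below. What is called first, only, known or untested is meant among the compounds shown, and "the series" means these compounds.

Working notes on the series. Compound 1 `CCNc1ncc(C(=O)O)c2nc(-c3ccco3)nn12` in an assay on CHO cells for displacement of a labelled ligand from adenosine receptor A3 (Homo sapiens) (a lower number here means a stronger inhibitor, a higher number a weaker inhibitor), gives 480 nM. Going by the values given here, compound 2 `CCCCC(CC)CNc1ncc(C(=O)O)c2nc(-c3ccco3)nn12` in this assay gives 16400 nM, the highest of the two numbers so far; the only measured step, a 34-fold higher number from compound 1 to compound 2 (1.53 log units; beyond the scatter), is the one that bears on the next change. Compound 3 `O=C(O)c1cnc(NCc2ccc(F)cc2)n2nc(-c3ccco3)nc12` differs from compound 2 by 4-fluorophenyl in place of 1-ethylpentyl on a saturated chain carbon bound to a nitrogen on an aromatic ring. Among the compounds with values here, since the sole step in hand concerns a lengthened chain rather than a ring, it guides the direction only loosely; a return toward the lower numbers is expected, and the step of an 11-fold lower number from compound 2 to compound 3 (1.04 log units; beyond the scatter) is the estimate. For compound 3 the expected value in this assay is 1500 nM, within 300 nM to 8000 nM.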

Compound 3, inhibition constant: 14000 nM
Compound 3: the middle estimate sits 9.3-fold (0.97 log units) below what was measured; the whole stated range lies below it.
By their numbers in this assay, from the lowest: compound 1; then compounds 3 and 2 (each within the scatter of the next).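

Putting 4-fluorophenyl in place of 1-ethylpentyl on a saturated chain carbon bound to a nitrogen on an aromatic ring leaves the number level (a 1.2-fold lower number from compound 2 to compound 3 (0.07 log units; within the scatter)), so a ring does no better here than the branched chain. Against methyl, the same 4-fluorophenyl gives a large change (a 29-fold higher number from compound 1 to compound 3 (1.46 log units; beyond the scatter)), and compound 1 alone stands apart among the three. No measured evidence on the cause of this result is available. The compounds shown leave open whether an unsubstituted phenyl, a propyl chain or an amine on the chain would stay near compound 1 or join compounds 2 and 3.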